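Swapping an Amine Link for a Carbamoyl Link

A few compounds are considered here, and "the series" means these few. Any claim that something is new, unique, unknown or untested is made for them only; others in the source may bear on it.

In a functional assay on MCF7 cells (Homo sapiens) for inhibition, read by sulforhodamine B assay, with a stated time of 48 h (a lower number here means a stronger inhibitor of growth, a higher number a weaker inhibitor of growth), compound 1 `CCCCCCCCCCCC[C@@H](O)[C@H]1CC[C@H]([C@H](O)CCCCCCCCCCNC(=O)c2ccnn2C)O1` gives 3240 nM and compound 2 `CCCCCCCCCCCC[C@@H](O)[C@H]1CC[C@H]([C@H](O)CCCCCCCCCCNCc2ccnn2C)O1` gives 1700 nM, so these two values sit within the scatter of each other. Compound 3 `CCCCCCCCCCCC[C@@H](O)[C@H]1CC[C@H]([C@H](O)CCCCCCCCCCC(=O)Nc2ccnn2C)O1` differs from compound 2 as follows: (1-methyl-1H-pyrazol-5-yl)carbamoyl in place of ((1-methyl-1H-pyrazol-5-yl)methyl)amino on a saturated chain carbon, ten or more bonds along the chain from an oxygen on a saturated carbon and a saturated ring carbon. For the measured compounds named here, the one measured step that bears on this change, a 1.9-fold lower number from compound 1 to compound 2 (0.28 log units; within the scatter), involves a similar link and is small. No step beyond the scatter is therefore expected, and the direction is uncertain. The estimated step is a 1.4-fold higher number from compound 2 to compound 3 (0.15 log units; within the scatter). The estimate for compound 3 is 2400 nM, with a range from 1000 nM to 6000 nM.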

Compound 3, concentration for 50% growth inhibition: 100000 nM
Compound 3: the middle estimate sits 42-fold (1.62 log units) below what was measured; the measured number lies above the stated range.
By their numbers in this assay, from the lowest: compounds 2 and 1 (each within the scatter of the next); then compound 3.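

In this assay the carbamoyl link proves far from interchangeable at this saturated chain carbon, with a 59-fold higher number from compound 2 to compound 3 (1.77 log units; beyond the scatter) and a 31-fold higher number from compound 1 to compound 3 (1.49 log units; beyond the scatter) for this one change. Compound 1 also has a carbonyl in its link, yet it stays within the scatter of compound 2, so a carbonyl alone does not set compound 3 apart; the way the link is built matters here.

On these data alone, whether a sulfonamide link or an ether link would behave like compound 2 or like compound 3 stays open. Nothing shown gives a reason for this drop.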